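Trimethoxyphenyl in Place of Fluorophenyl on the Shared Core

A few compounds are considered here, and "the series" means these few. Any claim that something is new, unique, unknown or untested is made for them only; others in the source may bear on it.

Of the compounds shown here, two have been measured. Compound 2 `COc1ccc2nc(NC(=O)c3cc(-c4ccc(F)cc4)n4nc(-c5ccccc5)cc4n3)sc2c1` carries a 4-fluorophenyl on the shared core; in a functional assay on DU-145 cells (Homo sapiens) for cytotoxicity, read by MTT assay, with a stated time of 48 h (on this read-out lower numbers stand for stronger inhibition and higher numbers for weaker inhibition), compound 2 gives 15400 nM. Compound 1 `COc1cc(-c2cc(C(=O)Nc3nc4ccc(F)cc4s3)nc3cc(-c4ccccc4)nn23)cc(OC)c1OC` differs from compound 2 at two places at once, and in this assay compound 1 gives 25700 nM. The two numbers lie within the usual scatter of each other, so compound 2 does not stand apart from compound 1 on what is known; both sit at the weak end of the read-out.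

Compound 3 `COc1ccc2nc(NC(=O)c3cc(-c4cc(OC)c(OC)c(OC)c4)n4nc(-c5ccccc5)cc4n3)sc2c1` is the next case: 3,4,5-trimethoxyphenyl in place of 4-fluorophenyl on an aromatic carbon. Among the measured compounds shown here, no pair measured so far differs in this one place alone, so no measured step sets the size of the change. For the measured compounds named here, the only guide is that compound 1, which carries the same entering group, gives 25700 nM, close to compound 2. The expected step from compound 2 to compound 3 is therefore small, a 1.3-fold higher number from compound 2 to compound 3 (0.11 log units; within the scatter), with no move beyond the scatter and, if anything, toward a weaker number. For compound 3 the estimate in this assay is 20000 nM, expected to fall between 8000 nM and 50000 nM.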

Compound 3, half-maximal inhibitory concentration: 3980 nM
For compound 3 the middle estimate is 5.0-fold (0.70 log units) above the measured one; the whole stated range lies above it.
By their numbers in this assay, from the lowest: compound 3; then compounds 2 and 1 (each within the scatter of the next).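

At the aromatic carbon next to the ring nitrogen, 3,4,5-trimethoxyphenyl in place of 4-fluorophenyl now has a measured size: with methoxy held at the other place, this assay shows a 3.9-fold lower number from compound 2 to compound 3 (0.59 log units; beyond the scatter) and places this change beyond the scatter. With 3,4,5-trimethoxyphenyl held instead, methoxy in place of fluoro on an aromatic carbon gives a 6.5-fold lower number from compound 1 to compound 3 (0.81 log units; beyond the scatter), so carrying the entering group does not alone set the number, and compound 1 goes against any reading of 3,4,5-trimethoxyphenyl as enough by itself. No measurement on hand bears on what lies behind either step.

Whether 3,4,5-trimethoxyphenyl in place of 4-fluorophenyl would also lower the number with fluoro at the other place remains open, as the compounds shown include no pair differing in that one place with fluoro held. Also open, on these data alone, is whether all three methoxy groups on the phenyl are needed, or whether a single methoxy, a hydroxy or a dimethylamino group there, or an amine in place of methoxy at the other place, would give a comparable number.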